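The source may report more compounds than this note shows. Statements on the series, on what has been measured and on what is new or still open speak of the compounds shown alone.

Working notes on the series.

Of the compounds shown here, two of the shared core have numbers so far. Compound 1 `COc1cc2c(Oc3ccc(NC(=O)c4cc(-c5ccc(C)cc5)nc5ccc(F)cc45)cc3F)ccnc2cc1OCCCN1CCCCC1` carries a 4-methylphenyl and an unsubstituted piperidine on the chain; in a functional assay on NCI-H460 cells (Homo sapiens) for cytotoxicity, read by MTT assay, with a stated time of 72 h (a lower number here means a stronger inhibitor, a higher number a weaker inhibitor), compound 1 gives 260 nM. Compound 2 `COc1cc2c(Oc3ccc(NC(=O)c4cc(-c5cccc(Cl)c5)nc5ccc(F)cc45)cc3F)ccnc2cc1OCCCN1CCC(C)CC1` carries a 3-chlorophenyl and a 4-methylpiperidine on the chain; in this assay compound 2 gives 60 nM. Compound 2 thus stands as the lower of the two numbers, and the gap to compound 1 lies beyond the usual scatter. Compound 1 and compound 2 differ in two places at once, so the two values alone cannot say which change carries the gap.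

Compound 3 `COc1cc2c(Oc3ccc(NC(=O)c4cc(-c5ccc(C)cc5)nc5ccc(F)cc45)cc3F)ccnc2cc1OCCCN1CCC(C)CC1` is the next member: it differs from compound 2 in one place, (4-methylphenyl in place of 3-chlorophenyl on an aromatic carbon), and so shares its 4-methylphenyl with compound 1 and its 4-methylpiperidine with compound 2. Because compound 1 gives 260 nM with the same 4-methylphenyl, the expected step of a 2.5-fold higher number from compound 2 to compound 3 (0.40 log units; beyond the scatter) runs toward a weaker value, though of modest size. For compound 3 the estimate in this assay is 150 nM, with a range from 60 nM to 400 nM.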

Compound 3, half-maximal inhibitory concentration: 480 nM
Compound 3: the middle estimate sits 3.2-fold (0.51 log units) below what was measured; the whole stated range lies below it.
By their numbers in this assay, from the lowest: compound 2; then compounds 1 and 3 (each within the scatter of the next).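

The single-place steps now split the gap that compounds 1 and 2 left unassigned. In this assay, at the aromatic carbon next to the ring nitrogen, 4-methylphenyl in place of 3-chlorophenyl gives an 8.0-fold higher number from compound 2 to compound 3 (0.90 log units; beyond the scatter), a step beyond the scatter with the 4-methylpiperidine held constant, while methyl in place of hydrogen on a saturated ring carbon gives a 1.8-fold higher number from compound 1 to compound 3 (0.27 log units; within the scatter), a step within the scatter with the 4-methylphenyl held constant. Of the two changes, only the exchange of aryl groups is resolved here, and nothing in hand explains the size of that step.

The exchange alters both the substituent and its place on the phenyl ring, so the compounds shown cannot separate chlorine from methyl or the 3-position from the 4-position; a 4-chlorophenyl or a 3-methylphenyl at this carbon would divide those two effects. From the compounds shown here alone, the piperidine methyl has also been read only alongside the 4-methylphenyl, so its step alongside the 3-chlorophenyl remains open, as does the effect of a morpholine at the end of the chain.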